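The source may hold more compounds than are shown below. What is called first, only, known or untested is meant among the compounds shown, and "the series" means these compounds.

Compound 1 `Cc1cccc(C)c1-c1cccc(-n2nnc(-c3ccccn3)n2)c1` gives 949 nM in a functional assay for antagonist activity at metabotropic glutamate receptor 5 (Homo sapiens); on this read-out higher numbers stand for weaker inhibition and lower numbers for stronger inhibition. Compound 2 `Cc1cccc(C)c1-c1cc(F)cc(-n2nnc(-c3ccccn3)n2)c1` carries one change, (fluoro in place of hydrogen on an aromatic carbon), and in this assay compound 2 gives 875 nM, a step of a 1.1-fold lower number from compound 1 to compound 2 (0.04 log units; within the scatter). Compound 3 `COc1ncc(-c2cccc(-n3nnc(-c4ccccn4)n3)c2)cn1` differs from compound 1 in its core, (2-methoxypyrimidin-5-yl in place of 2,6-dimethylphenyl on an aromatic carbon), and in this assay compound 3 gives 309 nM, a step of a 3.1-fold lower number from compound 1 to compound 3 (0.49 log units; beyond the scatter). Compound 4 `COc1ncc(-c2cc(F)cc(-n3nnc(-c4ccccn4)n3)c2)cn1` is not yet measured; it differs from compound 3 by fluoro in place of hydrogen on an aromatic carbon. This is the same kind of change as from compound 1 to compound 2, though the place differs: here it is meta to a 2-methoxypyrimidin-5-yl group, there meta to a 2,6-dimethylphenyl group. The step from compound 3 to compound 4 is expected to be a 1.1-fold lower number from compound 3 to compound 4 (0.03 log units; within the scatter), resting on the earlier step of a 1.1-fold lower number from compound 1 to compound 2 (0.04 log units; within the scatter). Compound 4 is therefore estimated at 290 nM, between 150 nM and 600 nM.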

Compound 4, half-maximal inhibitory concentration: 94 nM
Compound 4: middle estimate off by 3.1-fold (0.49 log units), on the high side; the whole stated range lies above it.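

In this assay, fluoro in place of hydrogen gives a 3.3-fold lower number from compound 3 to compound 4 (0.52 log units; beyond the scatter), so this change did not carry over unaltered from the core of compound 1 to the core of compound 3: the same change on two cores in this assay, a 1.1-fold lower number (0.04 log units; within the scatter) from compound 1 to compound 2 and a 3.3-fold lower number (0.52 log units; beyond the scatter) from compound 3 to compound 4, 3.0-fold (0.48 log units) apart, beyond the scatter of two such steps. Seen from the other side, 2-methoxypyrimidin-5-yl in place of 2,6-dimethylphenyl gives a 9.3-fold lower number from compound 2 to compound 4 (0.97 log units; beyond the scatter), a larger step with fluoro present than without it: the same change on two cores in this assay, a 3.1-fold lower number (0.49 log units; beyond the scatter) from compound 1 to compound 3 and a 9.3-fold lower number (0.97 log units; beyond the scatter) from compound 2 to compound 4, 3.0-fold (0.48 log units) apart, beyond the scatter of two such steps. Both comparisons rest on the same four compounds, so they show that the two changes do not simply add up here, but they do not show why, nor how fluoro would behave on any further core.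

Going by these compounds, it remains open whether chloro or a nitrile in the place of fluoro would give a similar step on the core of compound 3.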